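The source may hold more compounds than are shown below. What is called first, only, known or untested is meant among the compounds shown, and "the series" means these compounds.

In a functional assay on MCF7 cells (Homo sapiens) for antiproliferative activity, read by MTT assay, with a stated time of 48 h (a lower number here means a stronger inhibitor, a higher number a weaker inhibitor), compound 1 (`O=C(/C=C/c1ccc(C(F)(F)F)cc1)Nc1nnc(-c2ccc(Cl)cc2)s1`) gives 1.65 ug/mL and compound 2 (`O=C(/C=C/c1ccc(F)cc1)Nc1nnc(-c2ccc(Cl)cc2)s1`) gives 1.58 ug/mL, so compound 2 stands level with compound 1 within the scatter. Compound 3 (`COc1ccc(/C=C/C(=O)Nc2nnc(-c3ccc(Cl)cc3)s2)cc1`) carries methoxy in place of fluoro on an aromatic carbon, para to a large group: methoxy in place of fluoro on an aromatic carbon. Among the compounds with values here, the one measured step bearing on this change is a 1.0-fold lower number from compound 1 to compound 2 (0.02 log units; within the scatter), also a swap on an aromatic carbon, and it stays within the scatter. On that single step, no change beyond the scatter is expected in this assay, in either direction. The expected step is a 1.1-fold higher number from compound 2 to compound 3 (0.06 log units; within the scatter). Compound 3 is estimated at 1.8 ug/mL, with an expected range of 0.8 ug/mL to 4 ug/mL.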

Compound 3, half-maximal inhibitory concentration: 0.91 ug/mL
Compound 3: middle estimate off by 2.0-fold (0.30 log units), on the high side; measured number inside the range.
By their numbers in this assay, from the lowest: compounds 3, 2 and 1 (each within the scatter of the next).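

Methoxy, para to a large group, brings an oxygen absent from fluoro and trifluoromethyl, yet a 1.7-fold lower number from compound 2 to compound 3 (0.24 log units; within the scatter) and a 1.8-fold lower number from compound 1 to compound 3 (0.26 log units; within the scatter) both stay inside the scatter in this assay at this position. Compound 1, compound 2 and compound 3 thus show three different groups at this place with no step beyond the scatter. No measured evidence bears on the reason for this result.

From the compounds shown here alone, whether an amine, a carboxylic acid or a longer chain such as butoxy at this place would give a step beyond the scatter stays open.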